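Swapping Cyclohexyl for Pyridin-2-yl at a Crowded Carbon

This account rests on a few compounds, and the source may have more. Where it says the series, first, only, none or still open, it means among the compounds named here.

Compound 1 `Cc1nccn1CCC(C(N)=O)(c1ccccc1)C(C)C`: 394 nM
Compound 2 `Cc1nccn1CCC(C(N)=O)(c1ccccc1)C1CCCCC1`: 19 nM

Going by the values given here, in an assay on ileum with muscarinic acetylcholine receptor M3 (Cavia porcellus) as the target (a higher number here means a weaker inhibitor, a lower number a stronger inhibitor), compound 2 gives the lower of the two numbers, with compound 1 the only neighbour, and a 21-fold lower number from compound 1 to compound 2 (1.32 log units; beyond the scatter) shows that the group on this crowded carbon matters a great deal. Compound 3 `Cc1nccn1CCC(C(N)=O)(c1ccccc1)c1ccccn1` differs from compound 2 by pyridin-2-yl in place of cyclohexyl on a saturated chain carbon bound to an aromatic carbon, a carbonyl carbon and a saturated chain carbon. No measured step matches this change; the one step shown only concerns the size of a saturated group. Compound 3 is expected to be weaker, with an estimated step of a 6.3-fold higher number from compound 2 to compound 3 (0.80 log units; beyond the scatter), and its estimated value is 120 nM (range 30 nM to 500 nM).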

Compound 3, antagonist equilibrium constant: 2.86 nM
Beside the measured number, compound 3's estimate is 42-fold (1.62 log units) above it; the measured number lies below the stated range.
By their numbers in this assay, from the lowest: compound 3; then compound 2; then compound 1.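

In this assay, the crowded carbon accepts an aromatic ring as well as a saturated one, and pyridin-2-yl does better than cyclohexyl, with a 6.6-fold lower number from compound 2 to compound 3 (0.82 log units; beyond the scatter) on top of the gain already seen for cyclohexyl. Taken from the small isopropyl group, the full change is a 140-fold lower number from compound 1 to compound 3 (2.14 log units; beyond the scatter) at this one carbon, so a larger saturated group is not the only route to a lower number. No supporting data are available to explain why pyridin-2-yl gives the lower number. Still open, as far as these compounds go, is how a plain phenyl group would compare here, which would help separate the effect of the ring nitrogen from that of the aromatic ring. An amine or a longer chain on this carbon also remains untested within the compounds shown.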